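This account rests on a few compounds, and the source may have more. Where it says the series, first, only, none or still open, it means among the compounds named here.

In a functional assay on MCF7 cells (Homo sapiens) for cytotoxicity (a higher number here means a weaker inhibitor, a lower number a stronger inhibitor), compound 1 (`Nc1ccc(-c2nc3cc(O)ccc3s2)cc1`) gives > 100000 nM, which is a limit of the assay and not a number. Two relatives do give numbers: compound 2 (`CC(=O)Nc1ccc(-c2nc3cccc(O)c3s2)cc1C`) reads 48200 nM and compound 3 (`CC(=O)Nc1ccc(-c2nc3ccccc3s2)cc1O`) reads 9000 nM. Compound 4 (`Nc1ccc(-c2nc3cc(O)ccc3s2)cc1Cl`) differs from compound 1 by chloro in place of hydrogen on an aromatic carbon, ortho to an amino group and meta to a large group: chloro in place of hydrogen on an aromatic carbon. Within the data shown here, no measured pair in this assay isolates this change, so the forecast is loose. The expected step of an at least 1.6-fold lower number from compound 1 to compound 4 (0.22 log units; that floor lies within the scatter) is modest, towards stronger inhibition, and compound 4 may well stay at the limit. Compound 4 is estimated at 60000 nM, with an expected range from 15000 nM to 150000 nM.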

Compound 4, half-maximal inhibitory concentration: 60600 nM
Compound 4: middle estimate off by 1.0-fold (0.00 log units), on the low side, within the range that was stated.
By their numbers in this assay, from the lowest: compound 3; then compounds 2 and 4 (each within the scatter of the next). At a limit, above all of these: compound 1.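

In this assay, chloro in place of hydrogen on an aromatic carbon, ortho to an amino group, gives an at least 1.6-fold lower number from compound 1 to compound 4 (0.21 log units; that floor lies within the scatter). Compound 4 thus provides a number for this core where compound 1 gives only a limit, so this position can carry chloro without the reading staying at the limit. Only a floor can be read for the size of this change, because compound 1 has no numerical value: the limit of > 100000 nM in this assay, at which 1 of the 4 values shown sits.

As far as these compounds go, how a fluoro, bromo or methoxy group would read at this position remains open. So does whether any such group would move the number beyond the scatter.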